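The source may hold more compounds than are shown below. What is called first, only, known or untested is meant among the compounds shown, and "the series" means these compounds.

Values so far in an ADME assay on the whole organism for metabolic stability, with Rattus norvegicus as the target; on this read-out higher numbers stand for a longer-lived compound and lower numbers for a shorter-lived compound:
- compound 1 (`CSCC[C@H](NC(=O)c1ccc(CN(Cc2ccccc2)c2cnccn2)cc1-c1ccccc1C)C(=O)O`): < 0.4 h (a limit of the assay, not a number)
- compound 2 (`CSCC[C@H](NC(=O)c1ccc(CN(Cc2ccccc2)c2ccccc2)cc1-c1ccccc1C)C(=O)O`): 0.8 h
- compound 3 (`CSCC[C@H](NC(=O)c1ccc(CN(Cc2cc(F)cc(F)c2)c2ccccc2)cc1-c1ccccc1C)C(=O)O`): 1.9 h

Compound 2 holds the lower of the two actual numbers. The open case is compound 4 (`CSCC[C@H](NC(=O)c1ccc(CN(Cc2ccccc2)c2cncc(F)c2)cc1-c1ccccc1C)C(=O)O`), with 5-fluoropyridin-3-yl in place of phenyl on an amine nitrogen as its change from compound 2.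

Among the compounds with values here, only one measured step touches that amine nitrogen. Phenyl in place of pyrazin-2-yl there gave an at least 2.0-fold higher number from compound 1 to compound 2 (0.30 log units; that floor lies within the scatter) as its result. Read in reverse, this weakly suggests a lower number when a ring with a hetero atom replaces phenyl. The other step lies elsewhere, on a saturated chain carbon bound to a nitrogen on an aromatic ring. There, 3,5-difluorophenyl in place of phenyl gave a 2.4-fold higher number from compound 2 to compound 3 (0.38 log units; beyond the scatter) as its result, and whether a gain from fluorine carries over to the new place is not shown.

With these two hints pointing opposite ways, no clear change is expected. The expected size is a 1.1-fold lower number from compound 2 to compound 4 (0.06 log units; within the scatter) as an estimated step. For compound 4 the estimate is 0.7 h, with an expected range from 0.35 h to 1.5 h in this assay.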

Compound 4, half-life: < 0.4 h
Compound 4 was reported as a limit (the forecaster's own chance of this, stated with the estimate: 20%); middle value at least 1.7-fold (0.24 log units) from the limit.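

In this assay, 5-fluoropyridin-3-yl in place of phenyl on the amine nitrogen gives an at least 2.0-fold lower number from compound 2 to compound 4 (0.30 log units; that floor lies within the scatter). After compound 1, this is a second ring with a hetero atom at this place that falls on the low side of phenyl, though neither floor clears the scatter. Compound 4 is reported as a limit of the assay, < 0.4 h, and the step between compound 1 and compound 4 cannot be read, so the size of the drop stays a floor because of where the values stop: the limit of < 0.4 h in this assay, at which 2 of the 4 values shown sit.

A plain pyridinyl or a fluorophenyl group on this nitrogen would separate the part of the ring nitrogen from that of the fluorine. Also open, going by these compounds, is whether 3,5-difluorophenyl on the saturated chain carbon would lift compound 4 as it does in a 2.4-fold higher number from compound 2 to compound 3 (0.38 log units; beyond the scatter).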